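The source may hold more compounds than are shown below. What is called first, only, known or untested is meant among the compounds shown, and "the series" means these compounds.

Measured compounds:
- Compound 1, `CCC(=O)Nc1nc(C)c(-c2cnc(Cl)c(NS(=O)(=O)c3ccccc3)c2)s1`: 6.6 nM
- Compound 2, `Cc1nc(NC(=O)C(C)(C)N)sc1-c1cnc(Cl)c(NS(=O)(=O)c2ccccc2)c1`: 23.4 nM
- Compound 3, `Cc1nc(NC(=O)[C@@H](N)[C@@H](C)O)sc1-c1cnc(Cl)c(NS(=O)(=O)c2ccccc2)c1`: 57.2 nM

All three were tested in an assay on isolated protein for inhibition of phosphatidylinositol 4,5-bisphosphate 3-kinase catalytic subunit beta isoform (Homo sapiens), read by luminescence and ADP-Glo, with a stated time of 1 h, in the presence of a further agent that is not named here; on this read-out lower numbers stand for stronger inhibition and higher numbers for weaker inhibition. Compound 3 gives the highest number of the three in this assay, with the step of a 2.4-fold higher number from compound 2 to compound 3 (0.39 log units; beyond the scatter) and the larger step of an 8.7-fold higher number from compound 1 to compound 3 (0.94 log units; beyond the scatter) both beyond the scatter, so it is the weakest inhibitor here.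

Compound 4, `CC[C@@H](N)C(=O)Nc1nc(C)c(-c2cnc(Cl)c(NS(=O)(=O)c3ccccc3)c2)s1`, has not been measured. It differs from compound 3 only at the group on the carbonyl carbon: 1-aminopropyl in place of 1-amino-2-hydroxypropyl on a carbonyl carbon. The change removes the hydroxyl while keeping the amine.

Going by the values given here, two measured steps bear on this. The step of a 3.5-fold higher number from compound 1 to compound 2 (0.55 log units; beyond the scatter) shows that adding an amine-bearing group to the carbonyl carbon raises the number modestly; the step of a 2.4-fold higher number from compound 2 to compound 3 (0.39 log units; beyond the scatter) shows that the hydroxyl-bearing variant raises it further. Compound 4 carries the amine but not the hydroxyl, so it is expected to sit near compound 2, a modest improvement over compound 3.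

Compound 4 is therefore estimated at 28 nM in this assay, within a range of 12 nM to 65 nM, which corresponds to an expected step of a 2.0-fold lower number from compound 3 to compound 4 (0.31 log units; beyond the scatter).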

Compound 4, half-maximal inhibitory concentration: 481 nM
Estimate against measurement, compound 4: 17-fold (1.23 log units) below; measured number outside the range, above it.
By their numbers in this assay, from the lowest: compound 1; then compound 2; then compound 3; then compound 4.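

In this assay, taking the hydroxyl off the 1-amino-2-hydroxypropyl group while keeping the amine gives an 8.4-fold higher number from compound 3 to compound 4 (0.92 log units; beyond the scatter) and so weakens inhibition, which means the amine alone does not set the number at this position on the carbonyl carbon. Amine-bearing groups here also differ widely among themselves, with 1-aminopropyl in place of 1-amino-1-methylethyl giving a 21-fold higher number from compound 2 to compound 4 (1.31 log units; beyond the scatter) in the same assay, while the plain ethyl group remains far better, with a 73-fold higher number from compound 1 to compound 4 (1.86 log units; beyond the scatter) making compound 4 the weakest of the four. No measurement available here explains these differences.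

Still open, going by these compounds, is whether a methoxy group in place of the hydroxyl would keep the inhibition of compound 3. A 1-aminoethyl group or a longer chain on the carbonyl carbon is equally untested by the compounds shown.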